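Fluoro for methoxy on a nitro-bearing ring

This account rests on a few compounds, and the source may have more. Where it says the series, first, only, none or still open, it means among the compounds named here.

Measured so far:
compound 1 `COc1ccc(OC(C)(C)C2OCC(C/C=C\CCC(=O)O)C(c3cccnc3)O2)cc1` gives 302 nM
compound 2 `CC(C)(Oc1ccc(F)cc1)C1OCC(C/C=C\CCC(=O)O)C(c2cccnc2)O1` gives 120 nM
compound 3 `COc1ccc(OC(C)(C)C2OCC(C/C=C\CCC(=O)O)C(c3cccnc3)O2)c([N+](=O)[O-])c1` gives 6.17 nM

These three share one core and were tested in a functional assay for inhibition, with Homo sapiens as the target; a lower number here means tighter binding, a higher number weaker binding. Compound 1 and compound 2 differ by fluoro in place of methoxy on an aromatic carbon, and this change gave a 2.5-fold lower number from compound 1 to compound 2 (0.40 log units; beyond the scatter). Compound 3 carries the change nitro in place of hydrogen on an aromatic carbon relative to compound 1, and that step was a 49-fold lower number from compound 1 to compound 3 (1.69 log units; beyond the scatter); the related step of a 19-fold lower number from compound 2 to compound 3 (1.29 log units; beyond the scatter) is of the same large order. Compound 3 stands lowest of the three.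

Compound 4 `CC(C)(Oc1ccc(F)cc1[N+](=O)[O-])C1OCC(C/C=C\CCC(=O)O)C(c2cccnc2)O1` has not yet been measured in this assay. It differs from compound 3 by fluoro in place of methoxy on an aromatic carbon. This is the same kind of change as that between compound 1 and compound 2, but the place is not the same: in compound 4 the position is meta to a nitro group, which is absent in compound 2. The step from compound 3 to compound 4 in this assay is expected to be a 2.1-fold lower number from compound 3 to compound 4 (0.31 log units; beyond the scatter), resting on the modest step seen in a 2.5-fold lower number from compound 1 to compound 2 (0.40 log units; beyond the scatter). Compound 4 is therefore estimated to give 3 nM, between 1 nM and 10 nM.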

Compound 4, dissociation constant: 2.51 nM
The estimate for compound 4 lay 1.2-fold (0.08 log units) above the measured number; low and high end bracket the measured number.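

In this assay, fluoro in place of methoxy gave a 2.5-fold lower number from compound 3 to compound 4 (0.39 log units; beyond the scatter), and the step kept its size when carried from the core without the nitro group to the core with it: the same change on two cores in this assay, a 2.5-fold lower number (0.40 log units; beyond the scatter) from compound 1 to compound 2 and a 2.5-fold lower number (0.39 log units; beyond the scatter) from compound 3 to compound 4, 1.0-fold (0.01 log units) apart, within the scatter of two such steps

Nitro in place of hydrogen gave a 48-fold lower number from compound 2 to compound 4 (1.68 log units; beyond the scatter), and this step also kept its size whether the ring carried methoxy or fluoro: the same change on two cores in this assay, a 49-fold lower number (1.69 log units; beyond the scatter) from compound 1 to compound 3 and a 48-fold lower number (1.68 log units; beyond the scatter) from compound 2 to compound 4, 1.0-fold (0.01 log units) apart, within the scatter of two such steps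

With both changes together, the result was a 120-fold lower number from compound 1 to compound 4 (2.08 log units; beyond the scatter), which fits the two separate steps adding up, but this rests on four compounds in a single assay and one pair of changes, so it shows no general rule for this series and does not explain why the steps hold.

The compounds shown leave open whether the same agreement would hold for a nitrile or an amine in place of the nitro group, or for chloro in place of fluoro. They also leave open whether either step would keep its size if the carboxylic acid chain were shorter or longer.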